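Amine substituent on the quinone core: aryl in place of benzyl

The source may hold more compounds than are shown below. What is called first, only, known or untested is meant among the compounds shown, and "the series" means these compounds.

Three compounds on the shared core carry different amines on a double-bonded ring carbon. Compound 1 `O=C1C(NC2CC2)=CC(=O)c2c1nc1n2[C@H]2OC[C@@H](O)[C@H]2OC1` bears a cyclopropylamino group; in a functional assay on MGC-803 cells (Homo sapiens) for inhibition, read by sulforhodamine B assay (a higher number here means a weaker inhibitor, a lower number a stronger inhibitor), compound 1 is reported only as a limit of the assay, > 4000 nM. Compound 2 `O=C1C(N2CCCC2)=CC(=O)c2c1nc1n2[C@H]2OC[C@@H](O)[C@H]2OC1` bears a pyrrolidin-1-yl group, and in this assay compound 2 is likewise reported only as a limit, > 16000 nM. Compound 3 `O=C1C(NCc2ccccc2)=CC(=O)c2c1nc1n2[C@H]2OC[C@@H](O)[C@H]2OC1` bears a benzylamino group and is the only one of the three with a number: in this assay compound 3 gives 3490 nM. The measured steps read an at least 1.1-fold lower number from compound 1 to compound 3 (0.05 log units; that floor lies within the scatter), an at least 4.5-fold lower number from compound 2 to compound 3 (0.66 log units; beyond the scatter) and a step that the two limits leave unreadable from compound 1 to compound 2. Compound 3 thus stands at the only number shown, the other two values sitting at limits of this assay, the limit of > 16000 nM in this assay, at which 1 of the 3 values shown sits, and (the limit of > 4000 nM in this assay, at which 1 of the 3 values shown sits).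

Compound 4 `O=C1C(Nc2cccc(F)c2)=CC(=O)c2c1nc1n2[C@H]2OC[C@@H](O)[C@H]2OC1` differs from compound 3 by 3-fluorophenyl in place of benzyl on an amine nitrogen. Among the compounds with values here, no measured step exchanges an aryl for a benzyl on the amine nitrogen; the measured steps show only that a benzylamino group gives a number where cyclopropylamino and pyrrolidin-1-yl give limits. The change keeps one six-membered aromatic ring and the same count of heavy atoms, so for compound 4 in this assay no step beyond the scatter is expected, a 1.1-fold lower number from compound 3 to compound 4 (0.04 log units; within the scatter). Compound 4 is estimated at 3200 nM, between 1100 nM and 9500 nM, with a fair chance that only a limit is reported.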

Compound 4, half-maximal inhibitory concentration: 1470 nM
Compound 4: the middle estimate sits 2.2-fold (0.34 log units) above what was measured; low and high end bracket the measured number.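

Within the data shown here, the exchange of benzyl for 3-fluorophenyl on the amine nitrogen gives a 2.4-fold lower number from compound 3 to compound 4 (0.38 log units; beyond the scatter) in this assay, the first step at this position read between two numbers rather than against a limit. Against the two amines reported only as limits, the series now reads an at least 10-fold lower number from compound 2 to compound 4 (1.03 log units; beyond the scatter) and an at least 2.7-fold lower number from compound 1 to compound 4 (0.43 log units; beyond the scatter), both floors, and the second separates the cyclopropylamino compound where an at least 1.1-fold lower number from compound 1 to compound 3 (0.05 log units; that floor lies within the scatter) did not. Nothing measured here accounts for these steps.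

As far as these compounds go, the change from benzyl to 3-fluorophenyl alters the link to the ring and adds the fluorine in one move, so the shares of the two remain open, and a plain phenyl on the amine nitrogen would set them apart. Also open, from the compounds shown here alone, is whether the step depends on fluorine at all, which a 3-chlorophenyl or 3-methoxyphenyl group on the same nitrogen would test.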